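The source may hold more compounds than are shown below. What is called first, only, known or untested is meant among the compounds shown, and "the series" means these compounds.

Working notes on the series

Three members have been run in an assay on HEK293 cells for activation of Kir3.1/Kir3.2 (Homo sapiens), read by thallium flux; a higher number here means a larger maximal response, a lower number a smaller maximal response. Compound 1 `Cc1cc(NC(=O)Cn2nnc(-c3ccccc3)n2)n(C2CCS(=O)(=O)C2)n1` gives 93% in this assay. Compound 2 `Cc1nc(-c2ccccc2)c(NC(=O)Cn2nnc(-c3ccccc3)n2)s1`, built on a different core, gives "not active" (no number reported) in this assay, so it supplies no number. Compound 3 `Cc1cc(NC(=O)Cn2nnc(-c3cccc(Cl)c3)n2)n(C2CCCCC2)n1` gives 89% in this assay. On the two numbers available, compound 3 stands beside compound 1, the gap between them lying within the usual scatter of repeated measurements, and compound 2 stands apart without a number. For the measured compounds named here, no pair among the measured compounds differs in a single place, so no measured step exists.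

The next member is compound 4 `Cc1cccc(-c2nnn(CC(=O)Nc3cc(C)nn3C3CCCCC3)n2)c1`, which differs from compound 3 in one place: methyl in place of chloro on an aromatic carbon. Nothing in the measured set speaks to a methyl in this position, so the expectation rests on compound 3 alone, with its value 89% taken as the anchor. The step from compound 3 to compound 4 is expected to be small, a number 1 percentage points lower from compound 3 to compound 4 (within the scatter), in no preferred direction and not beyond the scatter. Compound 4 is therefore estimated at 88% in this assay, within a range of 70% to 102%.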

Compound 4, largest response reached (Emax), in percent of the reference or control that the assay uses: 93%
Compound 4: middle estimate off by 5 percentage points, on the low side; measured number inside the range.
By their numbers in this assay, from the lowest: compounds 3, 1 and 4 (each within the scatter of the next).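

Methyl in place of chloro on an aromatic carbon, meta to a large group, gives the first measured step in the series: in this assay the exchange reads as a number 4 percentage points higher from compound 3 to compound 4 (within the scatter), so the 3-chlorophenyl and 3-methylphenyl members cannot be told apart in this assay. At this position, one group can therefore stand in for the other without a separable change in maximal response, at least on the shared core of compound 3 and compound 4. No data at hand offer an explanation for this result.

On these data alone, whether the position also accepts an amine, a carboxylic acid or a longer chain such as propyl remains open. A single pair also leaves open whether the same exchange would read alike on the core of compound 2.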